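Shrinking the Amine Ring: Piperidin-1-yl to Pyrrolidin-1-yl

This account rests on a few compounds, and the source may have more. Where it says the series, first, only, none or still open, it means among the compounds named here.

Compound 1, `COc1ccc(-c2cc(C(=O)Nc3ccc(Oc4ccnc5cc(OCCCN6CCCCC6)c(OC)cc45)c(F)c3)c3ccccc3n2)cc1`: 210 nM
Compound 2, `COc1ccc(-c2cc(C(=O)Nc3ccc(Oc4ccnc5cc(OCCCN6CCCCC6)c(OC)cc45)c(F)c3)c3cc(F)ccc3n2)cc1`: 260 nM

For the measured compounds named here, in a functional assay on MKN-45 cells (Homo sapiens) for cytotoxicity, read by MTT assay, with a stated time of 72 h (a lower number here means a stronger inhibitor, a higher number a weaker inhibitor), compound 2 gives the larger of the two numbers, but the only measured step, a 1.2-fold higher number from compound 1 to compound 2 (0.09 log units; within the scatter), lies within the scatter, so the two values cannot be told apart. Compound 3, `COc1ccc(-c2cc(C(=O)Nc3ccc(Oc4ccnc5cc(OCCCN6CCCC6)c(OC)cc45)c(F)c3)c3cc(F)ccc3n2)cc1`, differs from compound 2 by pyrrolidin-1-yl in place of piperidin-1-yl on a saturated chain carbon, three bonds along the chain from an oxygen on an aromatic ring. Going by the values given here, no measured step touches this part of the molecule: the step of a 1.2-fold higher number from compound 1 to compound 2 (0.09 log units; within the scatter) concerns fluoro in place of hydrogen elsewhere, so no guidance exists for the amine ring. With nothing to point either way, no step beyond the scatter is expected, and the estimated step is no change at the digits printed from compound 2 to compound 3 (within the scatter). Compound 3 is therefore expected to give about 260 nM, within 120 nM to 560 nM.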

Compound 3, half-maximal inhibitory concentration: 170 nM
The estimate for compound 3 lay 1.5-fold (0.18 log units) above the measured number, within the range that was stated.
By their numbers in this assay, from the lowest: compounds 3, 1 and 2 (each within the scatter of the next).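

The step at this amine ring, a 1.5-fold lower number from compound 2 to compound 3 (0.18 log units; within the scatter) in this assay, shows that pyrrolidin-1-yl and piperidin-1-yl cannot be told apart at this position. Here the ring can go from six-membered to five-membered with no readable change in this cell read-out. No measured evidence bears on why this is so.

Still open, on these data alone, is how an open-chain amine such as dimethylamino, or a morpholin-4-yl ring, would read at this place. Also open, as far as these compounds go, is whether a longer chain than 3-(pyrrolidin-1-yl)propyl would matter.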